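Demethylation of a Methoxy Stilbene: Cytotoxicity Notes

This account rests on a few compounds, and the source may have more. Where it says the series, first, only, none or still open, it means among the compounds named here.

Measured so far:
- compound 1 `COc1ccc(/C=C/c2cc(C)n[nH]2)cc1`: 16500 nM
- compound 2 `COc1cc(/C=C/c2cc(C)no2)ccc1O`: 29800 nM

Both numbers come from an ADME assay on MDCK cells (Canis lupus familiaris) for cytotoxicity, read by MTT assay, with a stated time of 72 h; on this read-out lower numbers stand for stronger inhibition and higher numbers for weaker inhibition. For the measured compounds named here, compound 2 gives the highest of the two numbers, but its gap to compound 1 lies within the scatter, so the two compounds are not separated on this read-out; only two numbers exist, and no pattern is claimed from them.

The next compound, compound 3 `Cc1cc(/C=C/c2ccc(O)c(O)c2)on1`, differs from compound 2 in one place: hydrogen in place of methyl on an oxygen on an aromatic ring. Going by the values given here, no measured pair carries this change, so its effect is unknown here. With both measured numbers sitting close together in this assay , the step from compound 2 to compound 3 is expected to be small and is estimated as a 1.2-fold lower number from compound 2 to compound 3 (0.08 log units; within the scatter), with no direction claimed beyond the scatter. Compound 3 is therefore estimated at 25000 nM in this assay , with a range from 10000 nM to 60000 nM.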

Compound 3, half-maximal inhibitory concentration: 11600 nM
Compound 3: the middle estimate sits 2.2-fold (0.33 log units) above what was measured; low and high end bracket the measured number.
By their numbers in this assay, from the lowest: compounds 3, 1 and 2 (each within the scatter of the next, the first and the last beyond it).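

On the methoxy to hydroxy change, hydrogen in place of methyl on an oxygen on an aromatic ring gives a 2.6-fold lower number from compound 2 to compound 3 (0.41 log units; beyond the scatter) in this assay. For the compounds shown here, this is the first single-place step, and it shows that this oxygen is not a silent position on this read-out: removing one methyl moves the number beyond the scatter, though only modestly. No measured evidence bears on the reason for this shift.

Going by these compounds, the reading rests on one pair, so it remains open whether the shift holds on other cores, including that of compound 1. Also open, on these data alone, is how a longer chain such as ethyl on this oxygen, or an amine or a carboxylic acid in place of the hydroxy, would read in this assay.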